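This account rests on a few compounds, and the source may have more. Where it says the series, first, only, none or still open, it means among the compounds named here.

Working notes on the series. Compound 2 `Cc1ccc(Nc2nc(SCc3cn(CC(=O)NC(=O)Nc4ccccn4)nn3)nc(-c3ccc(C(C)C)cc3)c2C#N)cc1` gives the lowest number of the three measured, with 3060 nM in a functional assay on B16-F10 cells (Mus musculus) for inhibition, read by MTT assay, with a stated time of 72 h; on this read-out lower numbers stand for stronger inhibition and higher numbers for weaker inhibition. Compound 1 `CC(C)c1ccc(-c2nc(SCc3cn(CC(=O)NC(=O)Nc4ccccn4)nn3)nc(Nc3ccccc3)c2C#N)cc1` gives 14300 nM in this assay, and compound 3 `COc1ccccc1Nc1nc(SCc2cn(CC(=O)NC(=O)Nc3ccccn3)nn2)nc(-c2ccc(C(C)C)cc2)c1C#N` gives 34600 nM in this assay. The measured steps are a 4.7-fold lower number from compound 1 to compound 2 (0.67 log units; beyond the scatter), a 2.4-fold higher number from compound 1 to compound 3 (0.38 log units; beyond the scatter) and an 11-fold higher number from compound 2 to compound 3 (1.05 log units; beyond the scatter); all three concern the aryl group on the nitrogen, and the rest of the shared core is held constant throughout.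

Compound 4 `COc1cc(-c2nc(SCc3cn(CC(=O)NC(=O)Nc4ccccn4)nn3)nc(Nc3ccc(C)cc3)c2C#N)cc(OC)c1OC` has not been measured. It differs from compound 2 by 3,4,5-trimethoxyphenyl in place of 4-isopropylphenyl on an aromatic carbon. Among the measured compounds shown here, none of the measured steps concerns this aromatic carbon. For the measured compounds named here, the only step that introduces a methoxy, a 2.4-fold higher number from compound 1 to compound 3 (0.38 log units; beyond the scatter), is on the aryl group on the nitrogen, a different part of the molecule, so it gives no direct guide here. The direction of the change therefore cannot be read from the series, and the step is expected to be a 2.0-fold higher number from compound 2 to compound 4 (0.29 log units; within the scatter), with wide uncertainty either way. Compound 4 is expected to give 6000 nM in this assay, estimated between 1500 nM and 25000 nM.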

Compound 4, half-maximal inhibitory concentration: 32 nM
For compound 4 the middle estimate is 190-fold (2.27 log units) above the measured one; measured number outside the range, below it.
By their numbers in this assay, from the lowest: compound 4; then compound 2; then compound 1; then compound 3.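

Among the compounds shown here, the aromatic carbon ortho to the cyano group was held constant in the earlier compounds, and it now proves highly sensitive: in this assay, 3,4,5-trimethoxyphenyl in place of 4-isopropylphenyl gives a 96-fold lower number from compound 2 to compound 4 (1.98 log units; beyond the scatter), a larger step than any seen on the aryl group on the nitrogen. The entering group carries oxygen atoms and hydrogen-bond acceptors where the leaving group has none, but this single pair cannot show which of these differences, if any, matters, and the step shows only that this position tolerates a change of aryl group and can move the number strongly. No measurement at hand accounts for the size of this step.

As far as these compounds go, it remains open whether the full 3,4,5-trimethoxyphenyl group is needed, or whether a 4-methoxyphenyl, a 3,5-dimethoxyphenyl or a 4-hydroxyphenyl group at this position would give a similar number. Also open, from the compounds shown here alone, is whether the step carries over to the phenylamino and 2-methoxyphenylamino counterparts of compound 4, and how a 4-aminophenyl or 4-carboxyphenyl group would behave here.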